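Three Ureas at the Cytotoxicity Ceiling, a Fourth Expected There

This account rests on a few compounds, and the source may have more. Where it says the series, first, only, none or still open, it means among the compounds named here.

Compound 1 `O=C1N(CCCCCCOc2ccc(Br)cc2)CCN1c1ccncc1`, compound 2 `Cc1ccc(OCCCCCCN2CCN(c3ccncc3)C2=O)cc1` and compound 3 `O=C1N(CCCCCCOc2ccc(Br)cc2)CCN1c1cccnc1` were examined in a functional assay on cells (Homo sapiens) for cytotoxicity; on this read-out higher numbers stand for lower toxicity in this test and lower numbers for higher toxicity in this test. Compound 1 reached only the limit of > 25000 nM. Compound 2 likewise gave only the limit of > 25000 nM. Compound 3 too stopped at the limit of > 25000 nM. The change from compound 1 to compound 2 is methyl in place of bromo on an aromatic carbon, and its step is a step that the two limits leave unreadable from compound 1 to compound 2. The cores of compound 1 and compound 3 differ by pyridin-3-yl in place of pyridin-4-yl on an amide-type nitrogen in a ring, which gives a step that the two limits leave unreadable from compound 1 to compound 3. Compound 4 `Cc1ccc(OCCCCCCN2CCN(c3cccnc3)C2=O)cc1`, not yet measured, differs from compound 3 by the same change, (methyl in place of bromo on an aromatic carbon), at the same place. Compound 4 is expected, because of the limit of > 25000 nM in this assay, at which 3 of the 3 values shown sit, to lie a step that the limit leaves unreadable from compound 3 to compound 4 away. Compound 4 is therefore estimated at 30000 nM in this assay.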

Compound 4, half-maximal cytotoxic concentration: > 25000 nM
Compound 4: only a limit was reported (the forecaster's own chance of this, stated with the estimate: 85%); the middle value lies beyond the limit too.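

Compound 4 too gave only a limit, so its steps from compound 3 and compound 2 cannot be read in this assay. The compounds shown leave open how far each lies beyond that limit.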